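The compounds below may be only part of what the source reports. "The series", "measured", "known", "first", "only" and "open" are said of these compounds alone.

Working notes on the series.

Of the compounds shown here, two of the shared core have numbers so far. Compound 1 `COC(=O)C1=C(C)NC(=O)NC1c1ccoc1` in an assay on membranes from HeLa cells for displacement of a labelled ligand from adenosine receptor A3 (Homo sapiens), read by scintillation counting, with a stated time of 180 min, tested at 1 uM (on this read-out higher numbers stand for more inhibition at the one concentration tested (going by the name of the read-out) and lower numbers for less inhibition), gives 2%. Compound 2 `CC1=C(c2ncc(C)o2)C(c2ccco2)NC(=O)N1` in this assay gives 4%. Of these two numbers, that of compound 2 sits at the top, but compound 1 lies within the usual scatter of it, so the two cannot be told apart on this read-out; both sit near the floor of what the assay can show.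

Compound 3 `CC1=C(c2ncc(C)o2)C(c2ccoc2)NC(=O)N1` has not been measured. It differs from compound 2 by furan-3-yl in place of furan-2-yl on a saturated ring carbon. The two share every atom and differ only in how they are joined. Going by the values given here, no measured pair in this set isolates this change, so nothing here says how the read-out answers it, and the two numbers in hand are themselves alike.

For compound 3 a step of no change at the digits printed from compound 2 to compound 3 (within the scatter) is expected, that is, none beyond the scatter. Compound 3 is therefore estimated at 4%, with a range from -5% to 15%.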

Compound 3, a percentage reported as inhibition, at one concentration (the size of the read-out at that concentration, not a potency): 1%
Compound 3: the middle estimate sits 3 percentage points above what was measured; the measured number falls inside the stated range.
By their numbers in this assay, from the lowest: compounds 3, 1 and 2 (each within the scatter of the next).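

Furan-3-yl in place of furan-2-yl on the saturated ring carbon now has a pair that isolates it, and in this assay it reads as a number 3 percentage points lower from compound 2 to compound 3 (within the scatter), so the two furans cannot be told apart at the one concentration tested. With furan-3-yl held on that carbon, 5-methyl-1,3-oxazol-2-yl in place of methoxycarbonyl on the double-bonded ring carbon reads as a number 1 percentage points lower from compound 1 to compound 3 (within the scatter), so neither change shown here gives a step that stands clear of the scatter. Nothing in hand bears on why the read-out stays this flat.

All of these numbers lie near the floor of the read-out, so the absence of a step says little about how either place would respond once a compound of the series shows real inhibition. Open, on these data alone, are a phenyl ring or a longer alkyl chain in place of the furan on the saturated ring carbon, and a carboxylic acid or a primary amide in place of 5-methyl-1,3-oxazol-2-yl on the double-bonded ring carbon.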